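The source may hold more compounds than are shown below. What is called first, only, known or untested is meant among the compounds shown, and "the series" means these compounds.

Working notes on the series.

Compound 1 `O=C(Nc1cccc(-n2cc(-c3ccncc3)c(-c3cc(O)cc(Cl)c3)n2)c1)Nc1ccc(Cl)c(C(F)(F)F)c1` is the reference point here. In a functional assay on MDA-MB-435 cells (Homo sapiens) for inhibition, read by sulforhodamine B assay, with a stated time of 48 h, tested at 1 uM (on this read-out higher numbers stand for a weaker effect at the one concentration tested and lower numbers for a stronger effect), compound 1 gives 57%, which is the lowest of the two numbers in hand. Among the measured compounds shown here, its nearest neighbour is compound 2 `O=C(Nc1cccc(-n2cc(-c3ccncc3)c(-c3cc(O)cc(Cl)c3)n2)c1)Nc1ccc(Cl)c(Cl)c1`, which in this assay gives 79%; the step of a number 22 percentage points higher from compound 1 to compound 2 (beyond the scatter) is beyond the scatter and marks the only measured change in the set, chloro in place of trifluoromethyl on an aromatic carbon.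

Compound 3 `COc1cc(Cl)cc(-c2nn(-c3cccc(NC(=O)Nc4ccc(Cl)c(C(F)(F)F)c4)c3)cc2-c2ccncc2)c1` has not yet been measured in this assay. It differs from compound 1 by methyl in place of hydrogen on an oxygen on an aromatic ring, that is, hydroxy to methoxy on the 3-chloro-5-hydroxyphenyl group, giving 3-chloro-5-methoxyphenyl. For the measured compounds named here, no measured step touches this oxygen; the single step in hand concerns a different part of the molecule and gives no guide to the size or direction of a change here. With nothing to point one way or the other, the step of a number 5 percentage points higher from compound 1 to compound 3 (within the scatter) is expected to stay within the scatter, so the number is estimated to sit close to that of compound 1. For compound 3 in this assay the estimate is 62%, with a range from 45% to 80%.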

Compound 3, a percentage reported as activity, at one concentration (the size of the read-out at that concentration, not a potency): 81%
The estimate for compound 3 lay 19 percentage points below the measured number; the whole stated range lies below it.
By their numbers in this assay, from the lowest: compound 1; then compounds 2 and 3 (each within the scatter of the next).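

In this assay, hydroxy to methoxy on the 3-chloro-5-hydroxyphenyl group reads as a number 24 percentage points higher from compound 1 to compound 3 (beyond the scatter), so this oxygen is a position where a single added methyl changes the result, and the change is towards a weaker effect at the one concentration tested. The series now has a second responsive place on the core of compound 1, alongside the aromatic carbon that carries trifluoromethyl, where the change reads as a number 22 percentage points higher from compound 1 to compound 2 (beyond the scatter); both one-place changes in hand lead to a weaker effect, though two steps do not make a general rule. Nothing measured here bears on the reason for the shift at this oxygen.

Two compounds on this oxygen cannot separate the removal of the hydrogen from the addition of the methyl, and an amine or a fluorine in place of the hydroxy, or an ethoxy group in place of the methoxy, would put that question to the test. As far as these compounds go, it also remains open whether hydroxy to methoxy gives a step of similar size and direction when chloro stands in place of trifluoromethyl, as it does in compound 2.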